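This account rests on a few compounds, and the source may have more. Where it says the series, first, only, none or still open, it means among the compounds named here.

Compound 3 `CC(C)(C)c1cc2nn(-c3ccccc3)c(N)c2c(=O)[nH]1` gives 15% in an assay on isolated protein for inhibition of serine/threonine-protein kinase D2 (Homo sapiens), read by mobility shift assay, tested at 30 uM; a lower number here means less inhibition, a higher number more inhibition at the concentration tested (going by the name of the read-out). On that read-out compound 3 stands level with compound 1 `CN1CCN(c2ccc(-c3cc4[nH]nc(N)c4c(=O)[nH]3)cc2)CC1`, which gives 15% in this assay; together the two are the highest of the three measured. Going by the values given here, compound 2 `Cc1cc2nn(-c3ccccc3)c(N)c2c(=O)[nH]1` gives -1% in this assay, and the step of a number 16 percentage points higher from compound 2 to compound 3 (beyond the scatter) is the only measured change at the position now in question.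

Compound 4 `Nc1c2c(=O)[nH]c(-c3ccccc3)cc2nn1-c1ccccc1` differs from compound 3 as follows: phenyl in place of tert-butyl on an aromatic carbon. The step of a number 16 percentage points higher from compound 2 to compound 3 (beyond the scatter) shows a modest gain for a larger group at this carbon, but compound 1, carrying a substituted phenyl at the same carbon on a related core, is within the scatter of compound 3. A step of a number 3 percentage points higher from compound 3 to compound 4 (within the scatter) that stays within the scatter is therefore expected. Compound 4 is expected to give 18% in this assay, with a range from 0% to 40%.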

Compound 4, a percentage reported as inhibition, at one concentration (the size of the read-out at that concentration, not a potency): 23%
Estimate against measurement, compound 4: 5 percentage points below; low and high end bracket the measured number.
By their numbers in this assay, from the lowest: compound 2; then compounds 1, 3 and 4 (each within the scatter of the next).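

In this assay, phenyl at this carbon cannot be told apart from tert-butyl, with a number 8 percentage points higher from compound 3 to compound 4 (within the scatter). Set against methyl, however, phenyl gives a number 24 percentage points higher from compound 2 to compound 4 (beyond the scatter), so a ring of carbon here, like tert-butyl, stands clear of methyl. No available evidence accounts for these steps.

Going by these compounds, it remains open whether an amine or a carboxylic acid on this phenyl, or a longer chain at this carbon, would move the number beyond the scatter of compound 4. These readings, taken at one concentration, also leave the potency of all four compounds undefined.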